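This account rests on a few compounds, and the source may have more. Where it says the series, first, only, none or still open, it means among the compounds named here.

Compound 1 `COC(=O)c1ccc(-c2nn(-c3ccc(F)cc3F)cc2CNCCN2CCN(C)CC2)cc1` – in an ADME assay on Huh-7 cells (Homo sapiens) for cytotoxicity (on this read-out lower numbers stand for higher toxicity in this test and higher numbers for lower toxicity in this test), compound 1 gives > 20000 nM, which is a limit of the assay rather than a number.
Compound 2 `CN1CCN(CCNCc2cn(-c3ccc(F)cc3F)nc2-c2ccccc2Cl)CC1` – in this assay compound 2 gives > 20000 nM, again a limit of the assay.
Compound 3 `CN1CCN(CCNCc2cn(-c3ccc(F)cc3F)nc2-c2ccc(Cl)cc2)CC1` – in this assay compound 3 gives 19000 nM.

Within the data shown here, compound 3 thus holds the only true number among the three. The readings of compound 1 and compound 2 stop at the limit of > 20000 nM in this assay, at which 2 of the 3 values shown sit. The two steps that reach compound 3 are an at least 1.0-fold lower number from compound 1 to compound 3 (0.02 log units; that floor lies within the scatter) and an at least 1.0-fold lower number from compound 2 to compound 3 (0.02 log units; that floor lies within the scatter); each is held back by a limit and tells nothing beyond the scatter. Between compound 1 and compound 2 the step is a step that the two limits leave unreadable from compound 1 to compound 2.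

Compound 4 `CN1CCN(CCNCc2cn(-c3ccc(F)cc3F)nc2-c2cccc(N(C)C)c2)CC1` is not yet measured. It differs from compound 3 in one place: 3-(dimethylamino)phenyl in place of 4-chlorophenyl on an aromatic carbon. No measured step swaps in a ring that carries a dimethylamino group, so the change has no direct precedent among these compounds. Both steps that reach compound 3 stayed within the scatter, and nothing in these data points in a direction. For compound 4, then, a step of no change at the digits printed from compound 3 to compound 4 (within the scatter) is expected, that is, none beyond the scatter. Compound 4 is estimated at 19000 nM, with a range from 8000 nM to 40000 nM, and a fair chance that only a limit is reported.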

Compound 4, half-maximal cytotoxic concentration: > 20000 nM
Compound 4: only a limit was reported; the forecaster's own chance of this, stated with the estimate: 45%; middle value at least 1.0-fold (0.02 log units) away from the limit.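

Replacing 4-chlorophenyl with 3-(dimethylamino)phenyl gives an at least 1.0-fold higher number from compound 3 to compound 4 (0.02 log units; that floor lies within the scatter), so the first ring here to carry a dimethylamino group brings no readable shift in this assay. This position has now taken chloro-substituted rings, a ring with a methoxycarbonyl group and a ring with a nitrogen-bearing group, and the readings gather at one ceiling: the limit of > 20000 nM in this assay, at which 3 of the 4 values shown sit. The steps to compound 4 from compound 1 and from compound 2 cannot be read, as each has a limit at both ends.

With so many readings at a limit, the compounds shown do not reveal how much any of these rings truly differ from one another in this assay. From the compounds shown here alone, whether a phenyl ring bearing a carboxylic acid or a primary amine at this position, or a plain unsubstituted phenyl ring, would bring the number down beyond the scatter stays open.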